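The compounds below may be only part of what the source reports. "The series", "measured", "known", "first", "only" and "open" are said of these compounds alone.

Measured so far:
compound 1 `CC(C)n1cnc2c(Nc3cccc(Cl)c3)nc(NCOCc3ccc(C(=O)Nc4ccccc4N)cc3)nc21` — 63.4%
compound 2 `Nc1ccccc1NC(=O)/C=C/c1ccc(Cn2cnc3c(Nc4ccccc4)nc(Cl)nc32)cc1` — 30.9%

In a functional assay on HCT-116 cells (Homo sapiens) for antiproliferative activity, read by CCK-8 assay, with a stated time of 72 h, tested at 8 uM (on this read-out higher numbers stand for a stronger effect at the one concentration tested and lower numbers for a weaker effect), compound 1 gives 63.4%, the higher of the two numbers; compound 2 gives 30.9%, lower beyond the scatter. Within the data shown here, the two structures differ in several places at once, so no single step is drawn between them. Compound 3 `CC(C)n1cnc2c(Nc3ccccc3)nc(NCOCc3ccc(C(=O)Nc4ccccc4N)cc3)nc21` differs from compound 1 by hydrogen in place of chloro on an aromatic carbon: chloro leaves and hydrogen enters on an aromatic carbon of a six-membered aromatic ring of carbon only, meta to a large group. Among the measured compounds shown here, no measured pair isolates this change. A modest fall in this assay is expected, a number 11.4 percentage points lower from compound 1 to compound 3 (beyond the scatter), not clearly beyond the scatter. Compound 3 is estimated at 52% (32% to 68%).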

Compound 3, a percentage reported as inhibition, at one concentration (the size of the read-out at that concentration, not a potency): 18.8%
Compound 3: middle estimate off by 33.2 percentage points, on the high side, outside the stated range (below it).
By their numbers in this assay, from the lowest: compound 3; then compound 2; then compound 1.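

Hydrogen in place of chloro on this aromatic carbon gives, in this assay, a number 44.6 percentage points lower from compound 1 to compound 3 (beyond the scatter), a large step from the loss of one heavy atom. Among these compounds, since the two compounds differ only here, the read-out at this concentration depends strongly on this position of the (3-chlorophenyl)amino group, which the earlier compounds, differing in several places, could not show. Nothing at hand gives a reason for this step. On these data alone, whether fluoro, bromo or methoxy on the same carbon would serve like chloro stays open. As far as these compounds go, whether chloro elsewhere on this ring would do the same also stays open.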